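The source may hold more compounds than are shown below. What is called first, only, known or untested is meant among the compounds shown, and "the series" means these compounds.

Working notes on the series in a functional assay on 786-0 cells (Homo sapiens) for inhibition, read by sulforhodamine B assay, with a stated time of 48 h; a higher number here means that more compound is tolerated, a lower number that less compound is tolerated. All three measured compounds stop at a limit of the assay rather than at a number. Compound 1 `COc1cc(-c2nn(-c3cccc(NC(=O)c4ccc(Cl)c(C(F)(F)F)c4)c3)cc2-c2ccncc2)ccc1Cl` gives only a limit, > 32500 nM. Compound 2 `COc1cc(-c2nn(-c3cccc(NC(=O)Nc4ccc(Cl)c(C(F)(F)F)c4)c3)cc2-c2ccncc2)ccc1Cl` also gives only a limit, > 32500 nM. Compound 3 `COc1cc(-c2nn(-c3cccc(NC(=O)c4ccccc4)c3)cc2-c2ccncc2)ccc1Cl` gives only a limit as well, > 100000 nM. Compound 3 therefore has no readable place among the values: its own entry is a limit, and the other two entries are limits too, as summed up by the limit of > 100000 nM in this assay, at which 1 of the 3 values shown sits, and (the limit of > 32500 nM in this assay, at which 2 of the 3 values shown sit). The measured steps are accordingly blank in size: a step that the two limits leave unreadable from compound 1 to compound 2, a step that the two limits leave unreadable from compound 1 to compound 3 and a step that the two limits leave unreadable from compound 2 to compound 3.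

Compound 4 `COc1cc(-c2nn(-c3cccc(NC(=O)Nc4ccc(Cl)c(Cl)c4)c3)cc2-c2ccncc2)ccc1Cl` differs from compound 3 by (3,4-dichlorophenyl)amino in place of phenyl on a carbonyl carbon. The steps that touch the same carbonyl carbon, from compound 1 to compound 3 and from compound 2 to compound 3, are the ones that bear on this change, and both are unreadable, so no size or direction in this assay can be taken from them. For compound 4 the expected outcome is again a limit, the estimated step being an at least 2.0-fold lower number from compound 3 to compound 4 (0.30 log units; that floor lies within the scatter). Compound 4 is estimated at 50000 nM, with a range from 20000 nM to 150000 nM.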

Compound 4, concentration lethal to 50% of the cells: > 50000 nM
Compound 4 ended at the assay's limit (the forecaster's own chance of this, stated with the estimate: 75%); the middle value sits exactly at the limit.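

Compound 4, like compound 1, compound 2 and compound 3, stands at a limit in this assay, and its steps to those three cannot be read. The compounds shown leave open the size and direction of each change, and whether any of the four gives a number rather than a limit.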